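Compound 3: methoxy in place of nitro, expected cytotoxicity

The source may report more compounds than this note shows. Statements on the series, on what has been measured and on what is new or still open speak of the compounds shown alone.

Compound 2, `COc1cc2c(cc1OC)C(/C(C)=N/NC(N)=S)N(S(=O)(=O)c1ccc([N+](=O)[O-])cc1)CC2`, gives 42.3 ug/mL in a functional assay on MOLT-3 cells (Homo sapiens) for cytotoxicity, read by crystal violet staining, with a stated time of 3 days; a higher number here means a weaker inhibitor, a lower number a stronger inhibitor. Among the compounds with values here, that is the only number available in this assay; the other value shown is a limit. Compound 1, `COc1cc2c(cc1OC)C(/C(C)=N/NC(N)=S)N(S(=O)(=O)c1ccc(C)cc1)CC2`, sits at the limit of > 50 ug/mL in this assay, at which 1 of the 2 values shown sits, and its value of > 50 ug/mL in this assay is a limit and not a number. The step of an at least 1.1-fold lower number from compound 1 to compound 2 (0.07 log units; that floor lies within the scatter) is accordingly only a floor.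

Compound 3, `COc1ccc(S(=O)(=O)N2CCc3cc(OC)c(OC)cc3C2/C(C)=N/NC(N)=S)cc1`, differs from compound 2 as follows: methoxy in place of nitro on an aromatic carbon. Within the data shown here, the only measured step, an at least 1.1-fold lower number from compound 1 to compound 2 (0.07 log units; that floor lies within the scatter), touches the same aromatic carbon and shows no movement beyond the scatter; no measured step involves methoxy. Compound 3 is therefore expected to change by a 1.2-fold higher number from compound 2 to compound 3 (0.07 log units; within the scatter) in this assay, which is no step beyond the scatter. For compound 3 the estimate in this assay is 50 ug/mL, with a range from 28 ug/mL to 90 ug/mL, and a real chance that only a limit is reported.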

Compound 3, half-maximal inhibitory concentration: 2.13 ug/mL
For compound 3 the middle estimate is 23-fold (1.37 log units) above the measured one; measured number outside the range, below it.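

Within the data shown here, the aromatic carbon para to a large group showed no movement beyond the scatter in the only earlier step, but it responds strongly in this assay: methoxy in place of nitro gives a 20-fold lower number from compound 2 to compound 3 (1.30 log units; beyond the scatter). Methoxy in place of methyl on the same carbon gives an at least 23-fold lower number from compound 1 to compound 3 (1.37 log units; beyond the scatter), so among the compounds shown the 4-methoxyphenyl group stands apart from both the nitro and the methyl versions. That second step is only a floor, as compound 1 carries a limit and not a number: the limit of > 50 ug/mL in this assay, at which 1 of the 3 values shown sits.

The compounds shown leave open whether the drop belongs to methoxy alone or extends to other oxygen-linked groups, which a hydroxyl or an ethoxy group on this carbon would help to separate. On these data alone, whether an amine at this position behaves like methoxy or like nitro also stays open.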